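Working notes: compound 3 in the anilino sulfone series

The compounds below may be only part of what the source reports. "The series", "measured", "known", "first", "only" and "open" are said of these compounds alone.

Of the compounds shown here, two of the shared core have been measured in a functional assay on PC-3 cells (Homo sapiens) for cytotoxicity, read by MTT assay, with a stated time of 72 h; on this read-out lower numbers stand for stronger inhibition and higher numbers for weaker inhibition. Compound 1 `COc1ccc(Nc2nc3ccccc3nc2S(=O)(=O)c2ccc(Br)cc2)cc1` gives 1110 nM. Among the compounds with values here, compound 2 `COc1cc(Nc2nc3ccccc3nc2S(=O)(=O)c2ccc(Br)cc2)cc(OC)c1` gives 18200 nM, the highest of the two numbers, and the single measured step, a 16-fold higher number from compound 1 to compound 2 (1.21 log units; beyond the scatter), is what separates it from compound 1.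

Compound 3 `Nc1ccc(Nc2nc3ccccc3nc2S(=O)(=O)c2ccc(Br)cc2)cc1` is not yet measured. It differs from compound 2 in one place: 4-aminophenyl in place of 3,5-dimethoxyphenyl on a nitrogen on an aromatic ring. Within the data shown here, the one measured step bears on this change in reverse, since it ran from the 4-methoxyphenyl of compound 1 to the 3,5-dimethoxyphenyl of compound 2 and the number rose. Among the measured compounds shown here, compound 3 carries a 4-aminophenyl, closer in pattern to the 4-methoxyphenyl of compound 1 than to the 3,5-dimethoxyphenyl of compound 2, but no measured step covers the exchange of methoxy for amino, so the return may be partial. The step from compound 2 to compound 3 is therefore expected to be a 9.1-fold lower number from compound 2 to compound 3 (0.96 log units; beyond the scatter), towards lower numbers in this assay. Compound 3 is estimated at 2000 nM, within 500 nM to 8000 nM.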

Compound 3, half-maximal inhibitory concentration: 2330 nM
Compound 3: middle estimate off by 1.2-fold (0.07 log units), on the low side; measured number inside the range.
By their numbers in this assay, from the lowest: compound 1; then compound 3; then compound 2.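

In this assay, within the data shown here, the exchange of 3,5-dimethoxyphenyl for 4-aminophenyl on a nitrogen on an aromatic ring gives a 7.8-fold lower number from compound 2 to compound 3 (0.89 log units; beyond the scatter), which shows that the high number of compound 2 is not fixed by the shared core and that 4-methoxyphenyl is not the only group at this place to bring the number down. Among these compounds, the first direct reading of amino in place of methoxy on an aromatic carbon gives a 2.1-fold higher number from compound 1 to compound 3 (0.32 log units; beyond the scatter), a modest step that is still printed as beyond the scatter and is far smaller than the change seen on leaving 3,5-dimethoxyphenyl. Among these three compounds, both groups with a single substituent give lower numbers than 3,5-dimethoxyphenyl, with none going against this, but no measurement on hand accounts for the order.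

The compounds shown leave open whether the high number of compound 2 follows from the count of methoxy groups or from where they stand on the ring. They also leave open how far the number moves with other groups in place of amino on that aromatic carbon, such as a hydroxy, a dimethylamino or an acetamido group.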